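A Methoxy Swap on the Triazole Nitrogen Aryl Group

A few compounds are considered here, and "the series" means these few. Any claim that something is new, unique, unknown or untested is made for them only; others in the source may bear on it.

Compound 1 `Clc1ccc(-n2cc(COc3cccc4cnc(Nc5cccc(Cl)c5)nc34)nn2)cc1`: > 25000 nM
Compound 2 `Clc1cccc(Nc2ncc3cccc(OCc4cn(-c5ccc(Br)cc5)nn4)c3n2)c1`: 9000 nM

Going by the values given here, in a functional assay on MCF7 cells (Homo sapiens) for cytotoxicity, read by cell counting, with a stated time of 48 h (on this read-out higher numbers stand for weaker inhibition and lower numbers for stronger inhibition), compound 2 gives 9000 nM, the only true number so far. Compound 1 reads > 25000 nM, and this value is a limit of the assay, not a number.

Compound 3 `COc1cccc(-n2cc(COc3cccc4cnc(Nc5cccc(Cl)c5)nc34)nn2)c1` carries 3-methoxyphenyl in place of 4-bromophenyl on an aromatic nitrogen. Among the compounds with values here, only one measured step bears on this change: an at least 2.7-fold lower number from compound 1 to compound 2 (0.44 log units; beyond the scatter). It swaps bromo in for chloro on an aromatic carbon and lies beyond the scatter. Compound 3 has no bromo, so the gain seen in that step may not carry over. A modest move towards weaker inhibition in this assay is expected, an estimated 1.7-fold higher number from compound 2 to compound 3 (0.22 log units; within the scatter). For compound 3 the estimated value is 15000 nM, with an expected range from 6000 nM to 35000 nM.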

Compound 3, half-maximal inhibitory concentration: 8000 nM
Compound 3: the middle estimate sits 1.9-fold (0.27 log units) above what was measured, and the stated range covers the measured number.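

The step from 4-bromophenyl to 3-methoxyphenyl on the aromatic nitrogen reads a 1.1-fold lower number from compound 2 to compound 3 (0.05 log units; within the scatter), so this assay cannot tell these two groups apart, and a bromine is not required at this position for a value of this size. Measured against 4-chlorophenyl, the same 3-methoxyphenyl group gives an at least 3.1-fold lower number from compound 1 to compound 3 (0.49 log units; beyond the scatter). Compound 1 stands at a limit of the assay, not a number, so this step fixes only the smallest possible size of the difference: the limit of > 25000 nM in this assay, at which 1 of the 3 values shown sits.

Going by these compounds, what 4-methoxyphenyl or 3-bromophenyl would read remains open, so the effect of the substituent's place on the ring cannot yet be separated from the effect of the substituent itself. Also open, on these data alone, is whether a phenyl ring carrying an amine or a carboxylic acid would be accepted here.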